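The compounds below may be only part of what the source reports. "The series", "measured", "known", "first", "only" and "open" are said of these compounds alone.

In a functional assay on A-375 cells (Homo sapiens) for inhibition, read by CCK-8 assay, with a stated time of 72 h, tested at 8 uM (a higher number here means more inhibition of growth at the concentration tested, a lower number less inhibition of growth), the measured compounds gave:

compound 1, `Nc1ccccc1NC(=O)c1ccc(CSc2nccc(C(F)(F)F)n2)cc1`, 80.1%
compound 2, `Nc1ccccc1NC(=O)c1ccc(CSc2ccc(Br)cc2)cc1`, 6.17%
compound 3, `Cc1cc(C)cc(SCc2ccc(/C=C/C(=O)Nc3ccccc3N)cc2)c1`, 2.49%

In this assay compound 2 stands second highest of these three numbers. Its nearest neighbour is compound 3, whose number lies within the scatter of it, so the two cannot be told apart; compound 1 lies far higher, beyond the scatter. Compound 4, `Cc1ccc(SCc2ccc(C(=O)Nc3ccccc3N)cc2)cc1`, differs from compound 2 in one place: methyl in place of bromo on an aromatic carbon. Going by the values given here, no pair of measured compounds shows what this exchange does, so the expected step is a small one, in no clear direction. Because compound 2 gives 6.17%, compound 4 is expected to stay close, with a step of a number 3.8 percentage points higher from compound 2 to compound 4 (within the scatter) that is expected to remain within the scatter. Compound 4 is estimated at 10%, between 0% and 30%.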

Compound 4, percent growth inhibition at one concentration: 67%
For compound 4 the middle estimate is 57 percentage points below the measured one; measured number above the stated range.
By their numbers in this assay, from the lowest: compounds 3 and 2 (each within the scatter of the next); then compound 4; then compound 1.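

In this assay, the step of a number 60.8 percentage points higher from compound 2 to compound 4 (beyond the scatter) shows that this position on the ring is far from indifferent, since exchanging a single bromo for a single methyl separates a nearly inactive compound from a clearly active one. The earlier compounds shown here contained no pair that could reveal this sensitivity. No available evidence accounts for the size of the step.

Going by these compounds, whether an amine, a methoxy group or a carboxylic acid at this position would keep the growth inhibition remains open. So does whether the same exchange has a comparable effect on other cores.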